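Ethyl in Place of 3-Chlorophenyl on the Ring Nitrogen

This account rests on a few compounds, and the source may have more. Where it says the series, first, only, none or still open, it means among the compounds named here.

Three amides built on one shared core have been measured in a functional assay on B16-F10 cells (Mus musculus) for antiproliferative activity, read by MTT assay, with a stated time of 48 h; on this read-out lower numbers stand for stronger inhibition and higher numbers for weaker inhibition. Compound 1 `O=C(/C=C/c1ccc(O)c(O)c1)N1CCN(c2ccccc2Cl)CC1` gives 1.82 ug/mL, compound 2 `O=C(/C=C/c1ccc(O)c(O)c1)N1CCN(c2cccc(Cl)c2)CC1` gives 1.71 ug/mL, and compound 3 `Cc1ccc(N2CCN(C(=O)/C=C/c3ccc(O)c(O)c3)CC2)c(C)c1` gives 1.43 ug/mL. Compound 2 thus stands second highest of the three numbers, with compound 1 nearest and compound 3 furthest, and all three values sit within the scatter of one another. The three steps among them, a 1.1-fold lower number from compound 1 to compound 2 (0.03 log units; within the scatter), a 1.3-fold lower number from compound 1 to compound 3 (0.10 log units; within the scatter) and a 1.2-fold lower number from compound 2 to compound 3 (0.08 log units; within the scatter), each exchange one substituted phenyl on the amine nitrogen in the ring for another, and none of them moves the number beyond the scatter.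

Compound 4 `CCN1CCN(C(=O)/C=C/c2ccc(O)c(O)c2)CC1` departs from compound 2 by ethyl in place of 3-chlorophenyl on an amine nitrogen in a ring. Among the compounds with values here, no measured step exchanges a phenyl ring on that nitrogen for a chain, so the three steps bear on this change only indirectly: across compounds 1, 2 and 3 the choice of phenyl substituent leaves this assay unmoved, but the data hold nothing on removing the ring itself. One therefore expects for compound 4 a step of a 1.8-fold higher number from compound 2 to compound 4 (0.24 log units; within the scatter), carrying considerable uncertainty. Compound 4 is estimated at 3 ug/mL, within a range from 1.2 ug/mL to 8 ug/mL.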

Compound 4, half-maximal inhibitory concentration: 6.44 ug/mL
Compound 4: middle estimate off by 2.1-fold (0.33 log units), on the low side; measured number inside the range.
By their numbers in this assay, from the lowest: compounds 3, 2 and 1 (each within the scatter of the next); then compound 4.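

In this assay this ring nitrogen proves sensitive to the phenyl ring as a whole, although it was insensitive to the choice among the substituted phenyl groups: ethyl in place of 3-chlorophenyl gives a 3.8-fold higher number from compound 2 to compound 4 (0.58 log units; beyond the scatter) and ethyl in place of 2,4-dimethylphenyl gives a 4.5-fold higher number from compound 3 to compound 4 (0.65 log units; beyond the scatter) while ethyl in place of 2-chlorophenyl gives a 3.5-fold higher number from compound 1 to compound 4 (0.55 log units; beyond the scatter) on the same read-out. All three steps lie beyond the scatter and run the same way, towards weaker inhibition, with no compound shown going against them, so this position tolerates exchanges among these substituted phenyl groups but not this exchange for ethyl. No measurement at hand speaks to what lies behind the change.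

Ethyl differs from the three phenyl groups both in lacking a ring and in its smaller count of heavy atoms, and the four compounds do not separate these two differences. A longer chain such as hexyl, a saturated ring such as cyclohexyl, or a benzyl group on the same nitrogen would bear on that question, as would an unsubstituted phenyl.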